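Series notes: amino in place of chloro, compound 1 to compound 3

The source may hold more compounds than are shown below. What is called first, only, known or untested is meant among the compounds shown, and "the series" means these compounds.

Measured so far in a functional assay on HCT-116 cells (Homo sapiens) for inhibition, read by MTT assay, with a stated time of 48 h; on this read-out lower numbers stand for stronger inhibition and higher numbers for weaker inhibition:
compound 1, `COc1cc(-c2cc(-c3ccc(Cl)cc3)nc(-c3ccccc3)n2)cc(OC)c1OC`, gives 7980 nM
compound 2, `COc1cc(-c2cc(-c3cccc4ccccc34)nc(-c3ccccc3)n2)cc(OC)c1OC`, gives 4930 nM

Compound 1 holds the highest of the two numbers in this assay; its nearest neighbour is compound 2, with a 1.6-fold lower number from compound 1 to compound 2 (0.21 log units; within the scatter). Compound 3, `COc1cc(-c2cc(-c3ccc(N)cc3)nc(-c3ccccc3)n2)cc(OC)c1OC`, differs from compound 1 by amino in place of chloro on an aromatic carbon. Going by the values given here, no measured step swaps a halogen for an amino group, so the only bearing is the single step from compound 1 to compound 2, which is within the scatter. Compound 3 is therefore expected to show no change beyond the scatter, estimated at 6500 nM with a range of 2200 nM to 19000 nM, that is an expected 1.2-fold lower number from compound 1 to compound 3 (0.09 log units; within the scatter).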

Compound 3, half-maximal inhibitory concentration: 12300 nM
Estimate against measurement, compound 3: 1.9-fold (0.28 log units) below, and the stated range covers the measured number.
By their numbers in this assay, from the lowest: compounds 2, 1 and 3 (each within the scatter of the next, the first and the last beyond it).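

In this assay, amino in place of chloro at this position gives a step within the scatter (a 1.5-fold higher number from compound 1 to compound 3 (0.19 log units; within the scatter)), so these data do not separate 4-aminophenyl from 4-chlorophenyl, even though amino adds a hydrogen-bond donor and acceptor. Going by these compounds alone, the only step here beyond the scatter is modest (a 2.5-fold higher number from compound 2 to compound 3 (0.40 log units; beyond the scatter)) and comes with 4-aminophenyl in place of naphthalen-1-yl. No measurement at hand accounts for either step.

Open, from the compounds shown here alone, is whether a dimethylamino group, an acetamide or a carboxylic acid on this aromatic carbon would give a step from compound 1 beyond the scatter.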